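The source may hold more compounds than are shown below. What is called first, only, known or untested is meant among the compounds shown, and "the series" means these compounds.

Measured compounds:
- compound 1, `Cc1ccc(-c2nc3cccnc3o2)cc1`: 0%
- compound 2, `Clc1ccc(-c2nc3ncccc3o2)cc1`: 24%
- compound 3, `Brc1cccc(-c2nc3ncccc3o2)c1`: 23%

In a functional assay on the whole organism for inhibition, with Rattus norvegicus as the target, at a dose of 30 mg/kg (on this read-out higher numbers stand for more inhibition at the one dose given (going by the name of the read-out) and lower numbers for less inhibition), compound 1 gives 0%, the lowest of the three numbers. Its nearest neighbour is compound 3, whose value is higher by a margin beyond the scatter, and compound 2 stands further away still, also beyond the scatter. Compounds 2 and 3 are each within the scatter of one another, so no order between those two can be read from their values.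

The step under consideration leads from compound 1 to the unmeasured compound 4, `O=[N+]([O-])c1ccc(-c2nc3cccnc3o2)cc1`. The difference is nitro in place of methyl on an aromatic carbon. Within the data shown here, no step between measured compounds with exactly this change exists, so the expectation rests on the low standing of compound 1 and on the higher values seen for compounds 2 and 3 carrying other substituents on the same kind of ring.

Compound 4 is expected to show a modest rise over compound 1 in this assay, an estimated step of a number 20 percentage points higher from compound 1 to compound 4 (beyond the scatter), perhaps beyond the scatter but not far beyond it. The estimated value for compound 4 is 20%, with a range from 0% to 45%.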

Compound 4, a percentage reported as inhibition, in the whole organism at one dose (the size of the read-out at that dose, not a potency): 5%
Compound 4: middle estimate off by 15 percentage points, on the high side, and the stated range covers the measured number.
By their numbers in this assay, from the lowest: compounds 1 and 4 (each within the scatter of the next); then compounds 3 and 2 (each within the scatter of the next).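

In this assay, nitro in place of methyl on the aromatic carbon para to a group of 9 heavy atoms gives a number 5 percentage points higher from compound 1 to compound 4 (within the scatter). Among these compounds, this is the first pair here that differs in one place only, and it shows that at this position, at the one dose given, the two groups cannot be told apart, even though nitro brings more heavy atoms and two hydrogen-bond acceptors. Nothing measured here offers an explanation for this result.

From the compounds shown here alone, whether an amine, a carboxylic acid or a longer chain at this position would separate from compound 1 by more than the scatter stays open. Going by these compounds, how compound 2 and compound 3 relate to this pair also stays open, as neither differs from compound 1 or compound 4 in one place only.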